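A Trifluoromethyl Oxetane Replaces the Fluoromethyl Ethyl Group

This account rests on a few compounds, and the source may have more. Where it says the series, first, only, none or still open, it means among the compounds named here.

Of the compounds shown here, three that share one core have been tested in a functional assay on isolated protein for inhibition of Glucose-dependent insulinotropic receptor (Homo sapiens), read by HTRF and cAMP accumulation; a lower number here means that less compound is needed, a higher number that more compound is needed for the effect. Compound 2 `Cc1nc(S(C)(=O)=O)ccc1Oc1ncnc(OC2CCN(C(=O)O[C@H](C)CF)CC2)c1F` gives 196 nM, the highest number of the three. Compound 1 `Cc1nc(S(C)(=O)=O)ccc1Oc1ncnc(OC2CCN(C(=O)OC(C)(C)C#N)CC2)c1F` gives 92.9 nM, and compound 3 `CCC1(OC(=O)N2CCC(Oc3ncnc(Oc4ccc(S(C)(=O)=O)nc4C)c3F)CC2)CC1` gives 22 nM, the lowest. The three differ only in the group on an oxygen next to a carbonyl group, and all three steps between them are beyond the scatter: a 2.1-fold higher number from compound 1 to compound 2 (0.32 log units; beyond the scatter), a 4.2-fold lower number from compound 1 to compound 3 (0.63 log units; beyond the scatter) and an 8.9-fold lower number from compound 2 to compound 3 (0.95 log units; beyond the scatter).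

Compound 4 `Cc1nc(S(C)(=O)=O)ccc1Oc1ncnc(OC2CCN(C(=O)OC3(C(F)(F)F)COC3)CC2)c1F` carries a new group at that same place: 3-(trifluoromethyl)oxetan-3-yl in place of 1-(fluoromethyl)ethyl on an oxygen next to a carbonyl group. Within the data shown here, no measured step involves this new group, so the only guide is that both other groups tried at this position, in compound 1 and compound 3, gave lower numbers than compound 2. The new group differs more from anything already tested than those two did from each other, and it brings a ring, so the outcome is uncertain, but a lower number than that of compound 2 seems more likely than a higher one. The step from compound 2 to compound 4 is therefore expected to be a 2.5-fold lower number from compound 2 to compound 4 (0.39 log units; beyond the scatter). The estimate for compound 4 in this assay is 80 nM, with a range from 25 nM to 250 nM.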

Compound 4, half-maximal effective concentration: 29.3 nM
Compound 4: middle estimate off by 2.7-fold (0.44 log units), on the high side, and the stated range covers the measured number.
By their numbers in this assay, from the lowest: compounds 3 and 4 (each within the scatter of the next); then compound 1; then compound 2.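

In this assay, a group on an oxygen next to a carbonyl group can carry a ring with a hetero atom and still give one of the lower numbers, with a 6.7-fold lower number from compound 2 to compound 4 (0.83 log units; beyond the scatter) and a 3.2-fold lower number from compound 1 to compound 4 (0.50 log units; beyond the scatter) on the same scale. The 3-(trifluoromethyl)oxetan-3-yl group of compound 4 also stands level with the all-carbon 1-ethylcyclopropyl group of compound 3, since a 1.3-fold higher number from compound 3 to compound 4 (0.12 log units; within the scatter) leaves the two without any order. Across these four compounds the two groups with a ring give lower numbers than the two open-chain groups, and no compound goes against this, although no information on the cause is available here.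

Four compounds cannot separate the contribution of the ring from that of the trifluoromethyl group or the ring oxygen. On these data alone, an oxetane ring carrying a methyl group instead of the trifluoromethyl group, or a cyclobutyl ring carrying the trifluoromethyl group, would be needed to tell those parts apart, so their effect at this position remains open.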